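This account rests on a few compounds, and the source may have more. Where it says the series, first, only, none or still open, it means among the compounds named here.

Measured compounds:
Compound 1 `C=CCc1cc(O)c(O)c(CN2CCC(CCO)CC2)c1` gives 52.1% in a functional assay on HL-60 cells (Homo sapiens) for inhibition, read by MTT assay, with a stated time of 72 h, tested at 50 uM; on this read-out lower numbers stand for less inhibition of growth and higher numbers for more inhibition of growth at the one concentration tested.
Compound 2 `C=CCc1ccc(OCc2cn(-c3cccc(C#N)c3)nn2)c(O)c1` gives 30.9% in this assay.
Compound 3 `C=CCc1ccc(OCc2cn(-c3cccc([N+](=O)[O-])c3)nn2)c(O)c1` gives 65.5% in this assay.

Compound 2 stands lowest of the three numbers shown. Its nearest neighbour is compound 1, whose value lies higher by more than the usual scatter, and the furthest is compound 3. Compound 4 `C=CCc1ccc(OCc2cn(-c3ccc(OC)cc3)nn2)c(O)c1` has not yet been measured. It differs from compound 2 in one place: 4-methoxyphenyl in place of 3-cyanophenyl on an aromatic nitrogen.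

Going by the values given here, only one measured step changes the same position on the triazole-bound ring, and it is of another kind: a number 34.6 percentage points higher from compound 2 to compound 3 (beyond the scatter), where nitro replaced cyano. Among the compounds with values here, that step shows the group on this phenyl ring can move the read-out strongly, but no measured pair exchanges cyano for methoxy, or moves a group from one position of this ring to another, so the direction for compound 4 is not fixed by the data. The nitro step argues that a change here is likely to exceed the scatter in some direction. Compound 4 is therefore expected to show a modest rise, a number 7.1 percentage points higher from compound 2 to compound 4 (within the scatter), with wide uncertainty, and the estimate for compound 4 in this assay is 38%, lying between 15% and 62%.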

Compound 4, percent growth inhibition at one concentration: 38.9%
Compound 4: middle estimate off by 0.9 percentage points, on the low side, within the range that was stated.
By their numbers in this assay, from the lowest: compounds 2 and 4 (each within the scatter of the next); then compound 1; then compound 3.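

In this assay, putting 4-methoxyphenyl in place of 3-cyanophenyl on the aromatic nitrogen gives a number 8 percentage points higher from compound 2 to compound 4 (within the scatter) on this read-out, so these two compounds cannot be told apart. The earlier step, a number 34.6 percentage points higher from compound 2 to compound 3 (beyond the scatter) when nitro replaced cyano, had shown only that the group on this phenyl ring can move the read-out strongly; the new pair shows that not every exchange at this place does so, even one that changes both the group on the phenyl ring and where it sits. Nothing given here accounts for why one exchange at this place gives a large step and the other does not.

The compounds shown leave open how much of this result belongs to the methoxy group itself and how much to its place on the phenyl ring, since the two change together in this one step. They also leave open what an amine or a carboxylic acid on this phenyl ring would give in this assay and whether either would follow the nitro compound or the methoxy compound.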